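The compounds below may be only part of what the source reports. "The series", "measured", "known", "first", "only" and "open" are said of these compounds alone.

Compound 1 `CCCCSCC(=O)N1N=C(c2cc3ccccc3oc2=O)C[C@@H]1c1ccccc1` gives 12900 nM
Compound 2 `O=C(CSc1ncccn1)N1N=C(c2cc3ccccc3oc2=O)C[C@@H]1c1ccc(C(F)(F)F)cc1` gives 2890 nM
Compound 3 `O=C(CSCc1ccco1)N1N=C(c2cc3ccccc3oc2=O)C[C@@H]1c1ccc(C(F)(F)F)cc1` gives 15200 nM

All three values come from a functional assay on MGC-803 cells (Homo sapiens) for cytotoxicity, read by MTT assay, with a stated time of 48 h; a higher number here means a weaker inhibitor, a lower number a stronger inhibitor. Compound 3 cannot be separated from compound 1 within the scatter, while compound 2 has a lower number, beyond the scatter.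

Compound 4 `CCCCSCC(=O)N1N=C(c2cc3ccccc3oc2=O)C[C@@H]1c1ccc(C(F)(F)F)cc1` has propyl in place of furan-2-yl on a saturated chain carbon bound to a sulfur. For the measured compounds named here, the only measured step at this sulfur is a 5.3-fold higher number from compound 2 to compound 3 (0.72 log units; beyond the scatter), a modest one, and it involves a different group. Compound 1 also carries butylsulfanyl, at 12900 nM, but its core differs from that of compound 4. Going by the values given here, no measured step isolates that core difference. A step beyond the scatter is therefore not expected in this assay. The estimated step is a 1.4-fold lower number from compound 3 to compound 4 (0.14 log units; within the scatter). Compound 4 is expected at 11000 nM, within 4500 nM to 26000 nM.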

Compound 4, half-maximal inhibitory concentration: 2350 nM
The estimate for compound 4 lay 4.7-fold (0.67 log units) above the measured number, and the stated range ends above it.
By their numbers in this assay, from the lowest: compounds 4 and 2 (each within the scatter of the next); then compounds 1 and 3 (each within the scatter of the next).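

In this assay butyl on the sulfur gives a 6.5-fold lower number from compound 3 to compound 4 (0.81 log units; beyond the scatter), so the high number of compound 3 does not extend to this open chain, while butyl and pyrimidin-2-yl stay together at a 1.2-fold lower number from compound 2 to compound 4 (0.09 log units; within the scatter) within this pair. Trifluoromethyl in place of hydrogen on an aromatic carbon, now isolated with butylsulfanyl held constant, gives a 5.5-fold lower number from compound 1 to compound 4 (0.74 log units; beyond the scatter) as its first measured step. No measured evidence explains these steps.

Going by these compounds, whether the trifluoromethyl step carries over to compounds with pyrimidin-2-yl or (furan-2-yl)methyl on the sulfur stays open. So does the response at this sulfur to a longer chain or an amine.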